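The compounds below may be only part of what the source reports. "The series", "measured", "known", "first", "only" and "open" are said of these compounds alone.

Compound 1, `CCCCCCc1ccc(-c2noc(CCCN)n2)cc1`: 55% in an assay on HeLa cells for inhibition of sphingosine-1-phosphate transporter SPNS2 (Mus musculus), read by LC-MS, tested at 2 uM; a lower number here means less inhibition, a higher number more inhibition at the concentration tested (going by the name of the read-out)
Compound 2, `CCCCCCCCc1ccc(-c2noc(CCCN)n2)cc1`: 70% in this assay
Compound 3, `CCCCCCCCCc1ccc(-c2noc(CCCN)n2)cc1`: 61% in this assay

Going from compound 1 to compound 2 the change is ethyl in place of hydrogen on a saturated chain carbon, six bonds along the chain from an aromatic carbon, and the step was a number 15 percentage points higher from compound 1 to compound 2 (beyond the scatter). Going on to compound 3 the step was a number 9 percentage points lower from compound 2 to compound 3 (within the scatter). Compound 4, `CCCCCCCCCCCc1ccc(-c2noc(CCCN)n2)cc1`, is not yet measured. It differs from compound 3 by ethyl in place of hydrogen on a saturated chain carbon, nine bonds along the chain from an aromatic carbon. This is the same kind of change as from compound 1 to compound 2, but the place is not identical: there the ethyl entered six bonds along the chain from an aromatic carbon, here nine bonds along. The two cores differ by propyl in place of hydrogen on a saturated chain carbon, six bonds along the chain from an aromatic carbon. Because the step of a number 15 percentage points higher from compound 1 to compound 2 (beyond the scatter) was modest and the step of a number 9 percentage points lower from compound 2 to compound 3 (within the scatter) lay within the scatter, only a small step is expected here, a number 1 percentage points higher from compound 3 to compound 4 (within the scatter). Compound 4 is therefore estimated at 62%, likely between 42% and 80% in this assay.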

Compound 4, a percentage reported as inhibition, at one concentration (the size of the read-out at that concentration, not a potency): 49%
Compound 4: the middle estimate sits 13 percentage points above what was measured; the measured number falls inside the stated range.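

In this assay, adding ethyl gave a number 12 percentage points lower from compound 3 to compound 4 (beyond the scatter), which does not match the earlier ethyl step on the core of compound 1: the same change on two cores in this assay, a number 15 percentage points higher (beyond the scatter) from compound 1 to compound 2 and a number 12 percentage points lower (beyond the scatter) from compound 3 to compound 4, 27 percentage points apart, beyond the scatter of two such steps. Adding propyl gave a number 21 percentage points lower from compound 2 to compound 4 (beyond the scatter), which likewise does not match the earlier propyl step: the same change on two cores in this assay, a number 6 percentage points higher (within the scatter) from compound 1 to compound 3 and a number 21 percentage points lower (beyond the scatter) from compound 2 to compound 4, 27 percentage points apart, beyond the scatter of two such steps. A step measured on one core of this series therefore cannot simply be carried over to another, while adding pentyl gave a number 6 percentage points lower from compound 1 to compound 4 (within the scatter), and these four compounds do not show why the steps differ.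

Going by these compounds alone, it remains open how a longer chain than the one in compound 4 would read in this assay. On these data alone, it also remains open what a carboxylic acid in place of the amine would do.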